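Replacing a Benzyl Ether with a Pyridyl Ether

The compounds below may be only part of what the source reports. "The series", "measured", "known", "first", "only" and "open" are said of these compounds alone.

Measured so far in an in vitro ADME assay on microsomes from liver (Rattus norvegicus) for metabolic stability, tested at 5 uM; a lower number here means that the compound disappears faster, a higher number that the compound lasts longer:
Compound 1, `C=CC(=O)NCc1coc(-c2c(N)ncnc2Nc2ccc(OCc3cccc(F)c3)c(Cl)c2)n1`, gives 0.483 h.
Compound 2, `C=CC(=O)NCc1coc(-c2c(N)ncnc2Nc2ccc(Oc3ccccc3)c(Cl)c2)n1`, gives 0.983 h.
Compound 3, `C=CC(=O)NCc1coc(-c2c(N)ncnc2Nc2ccc(Oc3cccc(F)c3)c(Cl)c2)n1`, gives 0.9 h.

Compound 1 stands lowest of these three numbers in this assay. Compound 4, `C=CC(=O)NCc1coc(-c2c(N)ncnc2Nc2ccc(Oc3cccnc3)c(Cl)c2)n1`, differs from it in one place: pyridin-3-yl in place of 3-fluorobenzyl on an oxygen on an aromatic ring. Among the measured compounds shown here, two measured steps bear on this change, both taking the 3-fluorobenzyl off the oxygen in favour of a six-membered aromatic ring on that oxygen: a 2.0-fold higher number from compound 1 to compound 2 (0.31 log units; beyond the scatter) and a 1.9-fold higher number from compound 1 to compound 3 (0.27 log units; within the scatter). Between those two products the step of a 1.1-fold lower number from compound 2 to compound 3 (0.04 log units; within the scatter) lies within the scatter. A pyridin-3-yl on the same oxygen is therefore expected to give a modest rise of similar size, a 1.9-fold higher number from compound 1 to compound 4 (0.27 log units; within the scatter). Compound 4 is thus estimated at 0.9 h, with a range from 0.45 h to 1.8 h.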

Compound 4, half-life: 0.15 h
For compound 4 the middle estimate is 6.0-fold (0.78 log units) above the measured one; the whole stated range lies above it.
By their numbers in this assay, from the lowest: compound 4; then compounds 1, 3 and 2 (each within the scatter of the next, the first and the last beyond it).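

In this assay, a six-membered aromatic ring on this oxygen does not by itself set the outcome: pyridin-3-yl in place of 3-fluorobenzyl gives a 3.2-fold lower number from compound 1 to compound 4 (0.51 log units; beyond the scatter), against the direction of the phenyl step, a 2.0-fold higher number from compound 1 to compound 2 (0.31 log units; beyond the scatter). The hetero atom in the ring matters here, since pyridin-3-yl in place of phenyl gives a 6.6-fold lower number from compound 2 to compound 4 (0.82 log units; beyond the scatter) and in place of 3-fluorophenyl gives a 6.0-fold lower number from compound 3 to compound 4 (0.78 log units; beyond the scatter), while fluoro in place of hydrogen stays within the scatter.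

The data give no reason for this loss. On these data alone, whether it is particular to pyridin-3-yl remains open: pyridin-2-yl, pyridin-4-yl or pyrimidinyl on the same oxygen could show this.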